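A few compounds are considered here, and "the series" means these few. Any claim that something is new, unique, unknown or untested is made for them only; others in the source may bear on it.

Measured compounds in a functional assay on HeLa cells (Homo sapiens) for cytotoxicity, read by CCK-8 assay; on this read-out higher numbers stand for weaker inhibition and lower numbers for stronger inhibition:
compound 1 `Oc1ccc(-c2cc(-c3cccs3)cc(-c3cccc(O)c3)n2)cc1`: 4140 nM
compound 2 `Oc1cccc(-c2cc(-c3ccsc3)cc(-c3ccccc3O)n2)c1`: > 50000 nM
compound 3 `Oc1cccc(-c2cc(-c3ccco3)cc(-c3ccccc3O)n2)c1`: > 50000 nM

The value for compound 2 is a limit of this assay, not a number. The value for compound 3 is likewise a limit, not a number. Compound 1 is the only one of the three with a measured number. The step that the two limits leave unreadable from compound 2 to compound 3 therefore cannot be read in size, as both ends sit at the limit of > 50000 nM in this assay, at which 2 of the 3 values shown sit.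

Compound 4 `Oc1ccc(-c2cc(-c3ccco3)cc(-c3cccc(O)c3)n2)cc1` has not been measured. It differs from compound 3 by 4-hydroxyphenyl in place of 2-hydroxyphenyl on an aromatic carbon. For the measured compounds named here, compound 4 thus carries the 4-hydroxyphenyl and 3-hydroxyphenyl groups that compound 1 also carries, with furan-2-yl where compound 1 has thiophen-2-yl; no single step to compound 1 is measured, so only the two values themselves can be compared, and compound 1 sits at a measured number while compound 3 sits at a limit.

Going by the values given here, no measured step isolates the change from 2-hydroxyphenyl to 4-hydroxyphenyl. The expectation for compound 4 rests on compound 1 giving 4140 nM with the same pair of hydroxyphenyl groups. For compound 4 a step of an at least 5.5-fold lower number from compound 3 to compound 4 (0.74 log units; beyond the scatter) toward stronger inhibition is expected. Compound 4 is estimated at 9000 nM in this assay, within 2500 nM to 50000 nM.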

Compound 4, half-maximal inhibitory concentration: 5170 nM
Beside the measured number, compound 4's estimate is 1.7-fold (0.24 log units) above it; measured number inside the range.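

In this assay, for the compounds shown here, the position next to the ring nitrogen gives the first readable step, and it comes from changing only where the hydroxyl sits on the phenyl group: an at least 9.6-fold lower number from compound 3 to compound 4 (0.98 log units; beyond the scatter). The value of compound 3 is a limit and not a number, so this step has a lower bound but no exact size: the limit of > 50000 nM in this assay, at which 2 of the 4 values shown sit. With 4-hydroxyphenyl and 3-hydroxyphenyl both in place, furan-2-yl and thiophen-2-yl are not separated by this read-out, a 1.2-fold higher number from compound 1 to compound 4 (0.10 log units; within the scatter), whereas the earlier step between thiophen-3-yl and furan-2-yl cannot be read because both of its ends are limits.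

Going by these compounds, it remains open whether the 4-hydroxyphenyl result depends on the hydroxyl itself or would also hold for plain phenyl, 4-methoxyphenyl or 4-aminophenyl at this position. The compounds shown also leave open whether the 3-hydroxyphenyl group contributes to the value of compound 4, and whether a basic amine or a carboxylic acid on either phenyl group would be tolerated in this assay.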